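A trifluoromethyl for an acrylate ester on the benzyl ring

The source may report more compounds than this note shows. Statements on the series, on what has been measured and on what is new or still open speak of the compounds shown alone.

Compound 3 `CCN(CC)c1ccc2cc(C(=O)c3ccc(N4CCN(C(=O)CN5CCN(Cc6ccc(/C=C/C(=O)OC)cc6)CC5)CC4)cc3)oc2c1` gives 740 nM in a functional assay on SGC-7901 cells (Homo sapiens) for cytotoxicity, read by MTT assay, with a stated time of 48 h (on this read-out higher numbers stand for weaker inhibition and lower numbers for stronger inhibition), the lowest of the two numbers measured here. Its nearest neighbour is compound 2 `C#CCN1CCN(CC(=O)N2CCN(c3ccc(C(=O)c4cc5ccc(N(CC)CC)cc5o4)cc3)CC2)CC1`, which in this assay gives 20100 nM; the step of a 27-fold lower number from compound 2 to compound 3 (1.43 log units; beyond the scatter) is large. Compound 1 `CCN(CC)c1ccc2cc(C(=O)c3ccc(N4CCN(C(=O)CN5CCN(S(=O)(=O)c6ccc(F)cc6)CC5)CC4)cc3)oc2c1` reaches only a limit in this assay, > 40000 nM, so no number is known for it (the limit of > 40000 nM in this assay, at which 1 of the 3 values shown sits). The step of an at least 1.9-fold lower number from compound 1 to compound 2 (0.29 log units; that floor lies within the scatter) therefore rests on a floor that lies within the scatter.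

Compound 4 `CCN(CC)c1ccc2cc(C(=O)c3ccc(N4CCN(C(=O)CN5CCN(Cc6ccc(C(F)(F)F)cc6)CC5)CC4)cc3)oc2c1` differs from compound 3 in one place: trifluoromethyl in place of 2-(methoxycarbonyl)ethenyl on an aromatic carbon. Both measured steps concern the group on the same ring nitrogen of the shared core, but neither is this exchange. The large step from compound 2 to compound 3 came with the arrival of the whole 4-(2-(methoxycarbonyl)ethenyl)phenyl group; compound 4 keeps that phenyl ring and changes only what sits on it. A modest rise in the number, or none beyond the scatter, is expected rather than a return to the level of compound 2. Compound 4 is therefore expected to give 1500 nM, within a range from 500 nM to 5000 nM. The expected step is a 2.0-fold higher number from compound 3 to compound 4 (0.31 log units; beyond the scatter).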

Compound 4, half-maximal inhibitory concentration: 32000 nM
The estimate for compound 4 lay 21-fold (1.33 log units) below the measured number; the measured number lies above the stated range.
By their numbers in this assay, from the lowest: compound 3; then compounds 2 and 4 (each within the scatter of the next). At a limit, above all of these: compound 1.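

In this assay, within the data shown here, keeping the phenyl ring is not enough, since a 43-fold higher number from compound 3 to compound 4 (1.64 log units; beyond the scatter): what sits on that ring, para to a large group, decides the outcome, which the earlier compounds could not show. The step of a 1.6-fold higher number from compound 2 to compound 4 (0.20 log units; within the scatter) lies within the scatter, so the large step of a 27-fold lower number from compound 2 to compound 3 (1.43 log units; beyond the scatter) does not recur with 4-(trifluoromethyl)phenyl, and in these compounds it appears only with 4-(2-(methoxycarbonyl)ethenyl)phenyl. Compound 1 gives only a limit, not a number, so the step of an at least 1.2-fold lower number from compound 1 to compound 4 (0.09 log units; that floor lies within the scatter) rests on a floor within the scatter and sets no order between the two: the limit of > 40000 nM in this assay, at which 1 of the 4 values shown sits.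

The compounds shown do not separate the parts of the 2-(methoxycarbonyl)ethenyl group, so it stays open whether the low number depends on the double bond, the ester or the whole group. A saturated 2-(methoxycarbonyl)ethyl chain, a carboxylic acid or an amide at the same place on the ring would each test one of these parts, and no reason for the large step can be given from these data.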